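A few compounds are considered here, and "the series" means these few. Any claim that something is new, unique, unknown or untested is made for them only; others in the source may bear on it.

Series notes on the shared core of compound 1 `Nc1ccccc1NC(=O)c1ccc(CSC(=S)N2CCc3ccc([N+](=O)[O-])cc32)cc1`. In a functional assay on HeLa cells (Homo sapiens) for antiproliferative activity, read by CCK-8 assay, with a stated time of 72 h, tested at 8 uM (a lower number here means a weaker effect, a higher number a stronger effect of the compound at the concentration tested), compound 1 gives 62.1%. Compound 2 `CN(Cc1cccnc1)C(=S)SCc1ccc(C(=O)Nc2ccccc2N)cc1` gives 68.7% in this assay. Compound 3 `Nc1ccccc1NC(=O)c1ccc(CSC(=S)N2CCN(Cc3ccncc3)CC2)cc1` gives 72.9% in this assay, the top number of the three. The number of compound 2 lies within the scatter of that of compound 3, so no order between those two is claimed. The number of compound 1 lies beyond the scatter of that of compound 3. Compound 4 `Nc1ccccc1NC(=O)c1ccc(CSC(=S)N2CCN(Cc3ccccc3)CC2)cc1` is not yet measured. Relative to compound 3 it carries phenyl in place of pyridin-4-yl on a saturated chain carbon bound to an amine nitrogen in a ring. Among the measured compounds shown here, no measured pair shows this change, so only a small step is expected: a number 2.9 percentage points lower from compound 3 to compound 4 (within the scatter), nothing beyond the scatter in either direction. Compound 4 is thus estimated at 70% in this assay, with a range from 58% to 82%.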

Compound 4, a percentage reported as inhibition, at one concentration (the size of the read-out at that concentration, not a potency): 31.3%
Compound 4: the middle estimate sits 38.7 percentage points above what was measured; the whole stated range lies above it.
By their numbers in this assay, from the lowest: compound 4; then compounds 1, 2 and 3 (each within the scatter of the next, the first and the last beyond it).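

In this assay, among the compounds shown here, phenyl in place of pyridin-4-yl on a saturated chain carbon bound to an amine nitrogen in a ring gives a number 41.6 percentage points lower from compound 3 to compound 4 (beyond the scatter) and is the first single-place comparison. This position is therefore sensitive, and in this pair the ring nitrogen of the pyridin-4-yl group separates a high read-out from a low one. No available evidence accounts for the step.

Going by these compounds, whether a pyridin-2-yl or pyrimidinyl group would keep the number of compound 3 remains open. So does whether a substituted phenyl, such as methoxyphenyl, would recover any of it.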